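Fluoro for Trifluoromethoxy on the Aromatic Carbon

The source may report more compounds than this note shows. Statements on the series, on what has been measured and on what is new or still open speak of the compounds shown alone.

Of the compounds shown here, two have been measured in an assay on cells for displacement of a labelled ligand from prostaglandin D2 receptor 2 (Homo sapiens), read by scintillation counting, with a stated time of 60 min; on this read-out lower numbers stand for stronger inhibition and higher numbers for weaker inhibition. Compound 1 `O=C(O)CCC(=O)N(C1CC1)[C@H]1c2ccccc2N(C(=O)c2cccc(OC(F)(F)F)c2)[C@H]2CC[C@H]21` stands at 5 nM, and compound 2 `O=C(O)COC(=O)N(C1CC1)[C@H]1c2ccccc2N(C(=O)c2ccc(F)cc2)[C@H]2CC[C@H]21` stands at 3.5 nM; the two values lie within the usual scatter of each other. Compound 3 `O=C(O)CCC(=O)N(C1CC1)[C@H]1c2ccccc2N(C(=O)c2cccc(F)c2)[C@H]2CC[C@H]21` differs from compound 1 in one place: fluoro in place of trifluoromethoxy on an aromatic carbon. Within the data shown here, no measured pair shows this change, so a step of modest size in either direction, or none beyond the scatter, is expected. Compound 3 is estimated at 8 nM, with a range from 2.5 nM to 30 nM. The expected step is a 1.6-fold higher number from compound 1 to compound 3 (0.20 log units; within the scatter).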

Compound 3, inhibition constant: 8.1 nM
For compound 3 the middle estimate is 1.0-fold (0.01 log units) below the measured one; the measured number falls inside the stated range.
By their numbers in this assay, from the lowest: compounds 2, 1 and 3 (each within the scatter of the next, the first and the last beyond it).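

In this assay, among these compounds, the change from 3-(trifluoromethoxy)phenyl to 3-fluorophenyl gives a 1.6-fold higher number from compound 1 to compound 3 (0.21 log units; within the scatter) and is the only single-place comparison at this position. Going from five heavy atoms to one leaves the number within the scatter, so on the core of compound 1 this position accepts either group. No evidence available here bears on why the number holds.

The compounds shown leave open whether a plain hydrogen, an amine or a carboxylic acid on this aromatic carbon would also keep the number. They also leave open how a longer chain such as butoxy would fare there.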